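Two Methyls Replace the Iodine on Compound 1's Sulfonamide Aryl

The source may report more compounds than this note shows. Statements on the series, on what has been measured and on what is new or still open speak of the compounds shown alone.

Compound 1 `O=C1NCCN1c1ccc(S(=O)(=O)Nc2ccc(I)cc2)cc1` is the reference: in a functional assay on MCF7 cells (Homo sapiens) for antiproliferative activity, read by sulforhodamine B assay, with a stated time of 48 h (a higher number here means a weaker inhibitor, a lower number a stronger inhibitor), compound 1 gives 600 nM, the only plain number shown. Compound 2 `CCCCCCCc1ccc(NS(=O)(=O)c2ccc(N3CCNC3=O)cc2)cc1` gives > 1000 nM, which is a limit of the assay rather than a number. Compound 3 `Cc1ccc(C)c(NS(=O)(=O)c2ccc(N3CCNC3=O)cc2)c1` differs from compound 1 by 2,5-dimethylphenyl in place of 4-iodophenyl on a sulfonamide nitrogen. Within the data shown here, the only measured step that bears on such a change at this ring, an at least 1.6-fold higher number from compound 1 to compound 2 (0.22 log units; that floor lies within the scatter), went towards a weaker inhibitor, so a modest rise is expected for compound 3, a 1.8-fold higher number from compound 1 to compound 3 (0.26 log units; within the scatter). Compound 3 is estimated at 1100 nM, between 400 nM and 3000 nM.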

Compound 3, half-maximal inhibitory concentration: 48 nM
Compound 3: middle estimate off by 23-fold (1.36 log units), on the high side; measured number outside the range, below it.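

Replacing 4-iodophenyl with 2,5-dimethylphenyl on the sulfonamide nitrogen gives a 13-fold lower number from compound 1 to compound 3 (1.10 log units; beyond the scatter), so changes to this ring can strengthen activity substantially, not only leave it unchanged or weaken it. The ring itself stays a six-membered aromatic ring of carbon, so the gain comes with swapping the iodine for two methyl groups. Compound 2 gave only a limit, not a number, so its step could not show how far this position can move: the limit of > 1000 nM in this assay, at which 1 of the 3 values shown sits.

The compounds shown leave open whether either methyl group alone carries the gain. Going by these compounds, how a methoxy group, a chlorine or an amine on this ring would compare also remains open.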